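Swapping selenium for sulfur in a quinoline-linked hydroxybutynyl chain

The source may report more compounds than this note shows. Statements on the series, on what has been measured and on what is new or still open speak of the compounds shown alone.

Of the compounds shown here, three built on one shared core have been tested in a functional assay on P388 cells (Mus musculus) for cytotoxicity, read by MTT assay, with a stated time of 72 h; on this read-out lower numbers stand for stronger inhibition and higher numbers for weaker inhibition. Compound 1 `OCC#CCSc1cnc2ccccc2c1SCC#CCO` gives 5.7 ug/mL. Compound 2 `C#CCSc1cnc2ccccc2c1[Se]CC#CCBr` gives 1.2 ug/mL. Compound 3 `C#CCSc1cnc2ccccc2c1[Se]CC#CCO` gives 3.1 ug/mL, the second highest of the three numbers; its number sits within the scatter of compound 1 but beyond the scatter of compound 2. Going by the values given here, the single step with a known size, a 2.6-fold higher number from compound 2 to compound 3 (0.41 log units; beyond the scatter), concerns the end of the chain and not the atom that joins it to the ring.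

Compound 4 `C#CCSc1cnc2ccccc2c1SCC#CCO` has not yet been measured. It differs from compound 3 as follows: a group of 6 heavy atoms (4 carbon, 1 oxygen, 1 sulfur; no ring) in place of a group of 6 heavy atoms (4 carbon, 1 oxygen, 1 selenium; no ring), on an aromatic carbon. Among the compounds with values here, no measured pair isolates this exchange of selenium for sulfur, so no step bears on it directly. Compound 1, which carries sulfur at both places, and compound 3 lie within the scatter of each other, which offers no reason to expect a large step. Compound 4 is therefore expected to give about 4 ug/mL, between 2 ug/mL and 8 ug/mL. That estimate means a 1.3-fold higher number from compound 3 to compound 4 (0.11 log units; within the scatter), a step expected to stay within the scatter.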

Compound 4, concentration for 50% inhibition: 4 ug/mL
For compound 4 middle estimate and measured number coincide at the digits printed; low and high end bracket the measured number.
By their numbers in this assay, from the lowest: compound 2; then compounds 3, 4 and 1 (each within the scatter of the next).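

In this assay the exchange of selenium for sulfur on this aromatic carbon, opposite the ring nitrogen, gives a 1.3-fold higher number from compound 3 to compound 4 (0.11 log units; within the scatter) and so leaves the two compounds indistinguishable, with the hydroxy end of the chain kept the same. Compound 4 also shows that hydrogen in place of hydroxymethyl on the triple-bonded carbon of the other chain gives a 1.4-fold lower number from compound 1 to compound 4 (0.15 log units; within the scatter) and does not separate that pair either. Only the exchange that removes selenium and bromine together gives a step beyond the scatter, a 3.3-fold higher number from compound 2 to compound 4 (0.52 log units; beyond the scatter), so among these compounds the separation of compound 2 goes with its bromo end.

As far as these compounds go, whether an amine or a longer chain at that end would separate from the hydroxy compounds remains open. Nothing available here explains any of these steps.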